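The compounds below may be only part of what the source reports. "The series", "measured", "known", "first", "only" and "open" are said of these compounds alone.

The measured compounds:
- compound 1, `CCc1cc(C(C)=O)c(O)cc1OCCCCCC(C)(C)C(=O)O`, 73% in an assay on isolated protein for binding affinity to leukotriene B4 receptor 1 (Homo sapiens), tested at 1 uM; a lower number here means less inhibition, a higher number more inhibition at the concentration tested (going by the name of the read-out)
- compound 2, `CCc1cc(C(C)=O)c(O)cc1OCCCC(C)(C)C(N)=O`, 51% in this assay
- compound 3, `CCc1cc(C(C)=O)c(O)cc1OCCCCCC(C)(C)c1nnnn1C`, 59% in this assay

Compound 3 stands second highest of the three in this assay; its gap to compound 2 is within the scatter, whereas compound 1 sits beyond the scatter above it. Two steps from compound 1 are known: a number 22 percentage points lower from compound 1 to compound 2 (beyond the scatter) and a number 14 percentage points lower from compound 1 to compound 3 (beyond the scatter). Both replace the carboxy end of the chain and both lower the read-out modestly.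

Compound 4, `CCc1cc(C(C)=O)c(O)cc1OCCCCCCc1nnn[nH]1`, has not yet been measured in this assay. It differs from compound 3 as follows: (1H-tetrazol-5-yl)methyl in place of 1-methyl-1-(1-methyl-1H-tetrazol-5-yl)ethyl on a saturated chain carbon, five bonds along the chain from an oxygen on an aromatic ring. For the measured compounds named here, no measured step bears on the loss of the two methyl groups at the chain end, and the change from a 1-methyl-1H-tetrazol-5-yl to a 1H-tetrazol-5-yl is also new here; the only related step, a number 14 percentage points lower from compound 1 to compound 3 (beyond the scatter), shows that the carboxy is the better end group among those tested. The expected outcome is therefore uncertain, with a step of a number 3 percentage points higher from compound 3 to compound 4 (within the scatter) estimated, roughly no change beyond the scatter. The estimate for compound 4 is 62%, between 40% and 84%.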

Compound 4, a percentage reported as inhibition, at one concentration (the size of the read-out at that concentration, not a potency): 60%
Beside the measured number, compound 4's estimate is 2 percentage points above it; the measured number falls inside the stated range.
By their numbers in this assay, from the lowest: compounds 2, 3 and 4 (each within the scatter of the next); then compound 1.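

In this assay, the change from compound 3 to compound 4 removes the two methyl groups at the chain end and the methyl on the tetrazole together, yet the step is a number 1 percentage points higher from compound 3 to compound 4 (within the scatter), so at this position (1H-tetrazol-5-yl)methyl reads like 1-methyl-1-(1-methyl-1H-tetrazol-5-yl)ethyl, even though it adds a hydrogen-bond donor. The amide end group of compound 2 is not separated from this tetrazole either, with a number 9 percentage points higher from compound 2 to compound 4 (within the scatter), while the carboxy end group keeps its lead, with a number 13 percentage points lower from compound 1 to compound 4 (beyond the scatter), making compound 4 the third end-group replacement that falls beyond the scatter below compound 1. No supporting measurement accompanies these results, and the numbers alone give no explanation for them.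

The compounds shown do not separate the contribution of the two chain-end methyl groups from that of the methyl on the tetrazole, since both change in the same step. As far as these compounds go, it also remains open how an amine or a sulfonic acid at the chain end would read, and whether a longer chain carrying the 1H-tetrazol-5-yl group would come closer to compound 1.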